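Thiophen-2-yl exchange on compound 3

The source may hold more compounds than are shown below. What is called first, only, known or untested is meant among the compounds shown, and "the series" means these compounds.

Values in a functional assay on HCT-116 cells (Homo sapiens) for inhibition, read by MTT assay, with a stated time of 72 h; on this read-out higher numbers stand for weaker inhibition and lower numbers for stronger inhibition:
- Compound 1 `Nc1ccccc1NC(=O)c1ccc(CNCc2nc(-c3ccc(Cl)cc3)no2)cc1`: 6810 nM
- Compound 2 `Nc1ccccc1NC(=O)c1ccc(CNCc2nc(-c3cccs3)no2)cc1`: 27200 nM
- Compound 3 `O=C(NO)c1ccc(CNCc2nc(-c3ccc(Cl)cc3)no2)cc1`: 30200 nM

Compound 3 stands within the scatter of compound 2, and both carry higher numbers than compound 1, as a 4.4-fold higher number from compound 1 to compound 3 (0.65 log units; beyond the scatter) shows. Compound 4 `O=C(NO)c1ccc(CNCc2nc(-c3cccs3)no2)cc1` differs from compound 3 by thiophen-2-yl in place of 4-chlorophenyl on an aromatic carbon. The exchange sits between two ring nitrogen atoms. Among the measured compounds shown here, the only measured precedent for this exchange is a 4.0-fold higher number from compound 1 to compound 2 (0.60 log units; beyond the scatter). It is a single pair, so a step of similar size or somewhat smaller, towards a higher number, is expected in this assay. The expected change is a 2.3-fold higher number from compound 3 to compound 4 (0.37 log units; beyond the scatter). Compound 4 is estimated at 70000 nM, with an expected range of 25000 nM to 200000 nM.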

Compound 4, half-maximal inhibitory concentration: > 100000 nM
Compound 4 was reported as a limit (the forecaster's own chance of this, stated with the estimate: 25%); middle value at least 1.4-fold (0.15 log units) from the limit.
By their numbers in this assay, from the lowest: compound 1; then compounds 2 and 3 (each within the scatter of the next). At a limit, above all of these: compound 4.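

Compound 4 is reported in this assay only as a limit, > 100000 nM. Thiophen-2-yl in place of 4-chlorophenyl gives an at least 3.3-fold higher number from compound 3 to compound 4 (0.51 log units; beyond the scatter), so the direction seen with the 2-aminophenyl amide also holds with the hydroxy amide. Hydroxy in place of 2-aminophenyl gives an at least 3.6-fold higher number from compound 2 to compound 4 (0.56 log units; beyond the scatter), so that direction now holds with thiophen-2-yl as well as with 4-chlorophenyl at this position.

On these data alone, whether either change has the same size on both cores remains open. Also open, as far as these compounds go, is how an amine or a carboxylic acid would read at this position in place of thiophen-2-yl.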